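The source may report more compounds than this note shows. Statements on the series, on what has been measured and on what is new or still open speak of the compounds shown alone.

Working notes on the pyrazolone amide series. Compound 1 `Cc1cc(=O)n(-c2ccccc2C(F)(F)F)nc1C(=O)Nc1ccc(Oc2ncnc3ccsc23)cc1` and compound 2 `Cc1cc(=O)n(-c2ccc(Br)cc2F)nc1C(=O)Nc1ccc(Oc2ncnc3ccsc23)cc1` share one core; compound 3 `Cc1cc(=O)n(-c2ccccc2C(F)(F)F)nc1C(=O)Nc1ccc(Oc2ncnc3sccc23)c(F)c1` and the not yet measured compound 4 `Cc1cc(=O)n(-c2ccc(Br)cc2F)nc1C(=O)Nc1ccc(Oc2ncnc3sccc23)c(F)c1` share another. In a functional assay on HepG2 cells (Homo sapiens) for cytotoxicity, read by MTT assay, with a stated time of 72 h (a higher number here means a weaker inhibitor, a lower number a stronger inhibitor), compound 1 gives 9230 nM, and compound 2 gives 10600 nM. Going by the values given here, the single change between them, (4-bromo-2-fluorophenyl in place of 2-(trifluoromethyl)phenyl on an aromatic nitrogen), made a step of a 1.1-fold higher number from compound 1 to compound 2 (0.06 log units; within the scatter). Compound 3 gives 14700 nM in this assay; its value and those of compound 1 and compound 2 sit within the usual scatter of one another, so no order among the three is claimed. The difference between the core of compound 1 and the core of compound 3 is not broken down here. Compound 4 arises from compound 3 by 4-bromo-2-fluorophenyl in place of 2-(trifluoromethyl)phenyl on an aromatic nitrogen, the same change at the same kind of place as that from compound 1 to compound 2. Among the compounds with values here, with only one prior instance of this change to rest on, the step from compound 3 to compound 4 is expected to be about as small, a 1.1-fold higher number from compound 3 to compound 4 (0.04 log units; within the scatter), because the earlier instance gave a 1.1-fold higher number from compound 1 to compound 2 (0.06 log units; within the scatter). Compound 4 is therefore estimated at 16000 nM in this assay, with a range of 8000 nM to 32000 nM.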

Compound 4, half-maximal inhibitory concentration: 13800 nM
Compound 4: middle estimate off by 1.2-fold (0.06 log units), on the high side, and the stated range covers the measured number.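

In this assay the change from 2-(trifluoromethyl)phenyl to 4-bromo-2-fluorophenyl on the core of compound 3 gives a 1.1-fold lower number from compound 3 to compound 4 (0.03 log units; within the scatter). Set beside the earlier instance, the two steps cannot be told apart: the same change on two cores in this assay, a 1.1-fold higher number (0.06 log units; within the scatter) from compound 1 to compound 2 and a 1.1-fold lower number (0.03 log units; within the scatter) from compound 3 to compound 4, 1.2-fold (0.09 log units) apart, within the scatter of two such steps. So in this cell assay the change carries from one core to the other with no step beyond the scatter, but this rests on only two matched pairs, gives no direction for the change, and does not show that the same would hold on any further core or in another assay.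

On these data alone, all four compounds carry a halogen-bearing phenyl on the aromatic nitrogen, so it remains open whether a different kind of group there, such as a phenyl bearing an amine or a carboxylic acid, would give a step beyond the scatter. Also open, as far as these compounds go, is how each separate difference between the two cores bears on the read-out, since these compounds do not break that difference down.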